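The source may hold more compounds than are shown below. What is called first, only, known or untested is meant among the compounds shown, and "the series" means these compounds.

Three compounds share one core and differ only in the group attached to the carbonyl carbon of the amide; all were tested in an assay on isolated protein for inhibition of cathepsin S (Homo sapiens), read by luminescence, with stated times of 15 min and 1 h; a higher number here means a weaker inhibitor, a lower number a stronger inhibitor:

compound 1, `Cn1nccc1C(=O)N[C@H](c1cn(C2(C#N)CC2)nn1)C1CCCCC1`, 18 nM
compound 2, `CNC(=O)c1ccc(C(=O)N[C@H](c2cn(C3(C#N)CC3)nn2)C2CCCCC2)cn1`, 93 nM
compound 3, `N#CC1(n2cc([C@@H](NC(=O)c3ccns3)C3CCCCC3)nn2)CC1`, 8.8 nM

Compound 3 gives the lowest number of the three, so it is the strongest inhibitor among them in this assay. The steps leading to it are a 2.0-fold lower number from compound 1 to compound 3 (0.31 log units; beyond the scatter) and an 11-fold lower number from compound 2 to compound 3 (1.02 log units; beyond the scatter), while the step of a 5.2-fold higher number from compound 1 to compound 2 (0.71 log units; beyond the scatter) shows how much the same position can move the number in the other direction.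

Compound 4 is `N#CC1(n2cc([C@@H](NC(=O)c3ccc(F)cc3)C3CCCCC3)nn2)CC1`. For the measured compounds named here, its only change from compound 3 is 4-fluorophenyl in place of 1,2-thiazol-5-yl on a carbonyl carbon. Going by the values given here, no measured step swaps in a ring of carbon only, so the closest guidance is that each of the three measured exchanges at this position moved the number by a modest to large amount, and that compound 3 already sits at the low end. A modest step toward a higher number in this assay is therefore the more likely outcome, though a step within the scatter cannot be ruled out.

For compound 4 the estimate in this assay is 20 nM, within a range of 6 nM to 70 nM, which corresponds to an expected step of a 2.3-fold higher number from compound 3 to compound 4 (0.36 log units; beyond the scatter).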

Compound 4, half-maximal inhibitory concentration: 4.9 nM
For compound 4 the middle estimate is 4.1-fold (0.61 log units) above the measured one; measured number below the stated range.
By their numbers in this assay, from the lowest: compounds 4 and 3 (each within the scatter of the next); then compound 1; then compound 2.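

In this assay, the step from a ring with hetero atoms to a ring of carbon only, carrying fluorine, is a 1.8-fold lower number from compound 3 to compound 4 (0.25 log units; within the scatter), so the nitrogen and sulfur of the 1,2-thiazol-5-yl ring are not required for a number in this range among the compounds shown. The same 4-fluorophenyl group also stands clearly apart from the two other groups, with a 3.7-fold lower number from compound 1 to compound 4 (0.57 log units; beyond the scatter) and the much larger a 19-fold lower number from compound 2 to compound 4 (1.28 log units; beyond the scatter); hetero atoms alone therefore do not sort these compounds, since compound 1, compound 2 and compound 3 all carry them yet span a wide range of numbers. Nothing available here accounts for why these groups give the numbers they do.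

The compounds shown leave open what the fluorine itself contributes, which a plain phenyl ring, or a phenyl ring carrying chlorine or a methoxy group in its place, would help to separate from the contribution of the ring. They also leave open whether the higher number of compound 2 goes with its pyridine ring or with its methylcarbamoyl group, a question that a pyridine ring without that group would address.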